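The source may report more compounds than this note shows. Statements on the series, on what has been measured and on what is new or still open speak of the compounds shown alone.

Working notes on the series. Among the measured compounds shown here, compound 3 `Cc1ccc(C(=O)NN(C(=O)c2cc(C)cc(C)c2)C(C)(C)C)cc1` sits at the low end of the three numbers so far: in an assay on cells for agonist activity at ecdysone receptor (Bombyx mori), read by a luciferase reporter, with a stated time of 24 h (on this read-out lower numbers stand for an effect already at smaller amounts and higher numbers for an effect only at larger amounts of compound), compound 3 gives 12 nM. Compound 1 `Cc1cc(C)cc(C(=O)N(NC(=O)c2ccccc2)C(C)(C)C)c1` gives 69.2 nM and compound 2 `COc1cccc(C(=O)NN(C(=O)c2cc(C)cc(C)c2)C(C)(C)C)c1` gives 66.1 nM, so the two sit together, and the step of a 1.0-fold lower number from compound 1 to compound 2 (0.02 log units; within the scatter) adds nothing beyond the scatter. The steps of a 5.8-fold lower number from compound 1 to compound 3 (0.76 log units; beyond the scatter) and a 5.5-fold lower number from compound 2 to compound 3 (0.74 log units; beyond the scatter) set compound 3 apart from both.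

Compound 4 `Cc1cc(C)cc(C(=O)N(NC(=O)c2ccc(Cl)cc2)C(C)(C)C)c1` differs from compound 3 in one place: chloro in place of methyl on an aromatic carbon, on an aromatic carbon of a six-membered aromatic ring of carbon only, para to a large group. For the measured compounds named here, no measured step swaps methyl for chloro, so the only bearing comes from what the methyl itself is worth: removing it, as in the step of a 5.8-fold lower number from compound 1 to compound 3 (0.76 log units; beyond the scatter) read backwards, costs a modest amount. Chloro keeps one heavy atom at the same place, so the expectation is a number near compound 3, with more room upward than downward.

The expected step is a 1.3-fold higher number from compound 3 to compound 4 (0.12 log units; within the scatter). For compound 4 the estimate in this assay is 16 nM, with a range from 5 nM to 50 nM.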

Compound 4, half-maximal effective concentration: 19.1 nM
Compound 4: middle estimate off by 1.2-fold (0.08 log units), on the low side, and the stated range covers the measured number.
By their numbers in this assay, from the lowest: compounds 3 and 4 (each within the scatter of the next); then compounds 2 and 1 (each within the scatter of the next).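

In this assay, the aromatic carbon para to a large group now carries either methyl or chloro, and the swap between them, a 1.6-fold higher number from compound 3 to compound 4 (0.20 log units; within the scatter), does not separate the two groups. Chloro in place of hydrogen at this place gives a 3.6-fold lower number from compound 1 to compound 4 (0.56 log units; beyond the scatter), in the same direction as a 5.8-fold lower number from compound 1 to compound 3 (0.76 log units; beyond the scatter), so the lower number seen with methyl is not unique to methyl among the groups shown here. The 4-chlorophenyl group also stands apart from the 3-methoxyphenyl group, with a 3.5-fold lower number from compound 2 to compound 4 (0.54 log units; beyond the scatter), which leaves compounds 3 and 4 together at the low end, although no measurement shown here bears on the cause of this pattern.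

The compounds shown leave open whether an amine, a carboxylic acid or a longer chain at this place would keep the number close to those of compound 3 and compound 4. They also leave open whether a methoxy group at this same place would behave like methyl and chloro, since compound 2 differs from compound 3 and compound 4 in a whole 3-methoxyphenyl group.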